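The source may report more compounds than this note shows. Statements on the series, on what has been measured and on what is new or still open speak of the compounds shown alone.

Series notes. The shared core carries a side chain ending in a cyclic amine. Compound 1 `Cc1cc(=O)oc2ccc(OCC(O)CN3CCCCC3)cc12` bears piperidin-1-yl; in a functional assay on ileum for antagonist activity at histamine H1 receptor (Cavia porcellus), tested at 0.1 mg/mL (on this read-out lower numbers stand for an effect already at smaller amounts and higher numbers for an effect only at larger amounts of compound), compound 1 gives 0.0055 ug/mL. Compound 2 `Cc1cc(=O)oc2ccc(OCC(O)CN3CCN(C)CC3)cc12` carries 4-methylpiperazin-1-yl in place of piperidin-1-yl on a saturated chain carbon, two bonds along the chain from an oxygen on a saturated carbon, and in this assay compound 2 gives 0.0058 ug/mL. Going by the values given here, that step, a 1.1-fold higher number from compound 1 to compound 2 (0.02 log units; within the scatter), lies within the scatter; compound 2 thus stands level with compound 1, the only other measured compound, with nothing separating the two beyond repeat variation.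

Compound 3 `COc1ccccc1N1CCN(CC(O)COc2ccc3oc(=O)cc(C)c3c2)CC1` is not yet measured. It differs from compound 2 by 2-methoxyphenyl in place of methyl on an amine nitrogen in a ring. Among the compounds with values here, no measured pair varies the group on that ring nitrogen; the only step available, a 1.1-fold higher number from compound 1 to compound 2 (0.02 log units; within the scatter), exchanges the whole ring and was flat. The data give no basis for a shift beyond the scatter in either direction, so the step of a 1.7-fold higher number from compound 2 to compound 3 (0.24 log units; within the scatter) is expected to be small, with a wide allowance for the larger group entering. Compound 3 is estimated at 0.01 ug/mL, with a range from 0.002 ug/mL to 0.05 ug/mL.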

Compound 3, half-maximal effective concentration: 0.0058 ug/mL
Compound 3: middle estimate off by 1.7-fold (0.24 log units), on the high side, and the stated range covers the measured number.
By their numbers in this assay, from the lowest: compounds 1, 2 and 3 (each within the scatter of the next).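

Going by these compounds alone, on the amine nitrogen in the ring, 2-methoxyphenyl in place of methyl gives no change at the digits printed from compound 2 to compound 3 (within the scatter) in this assay, the first step that changes the group on that nitrogen while the ring itself stays the same. The read-out of this assay therefore gives no sign of a penalty or a gain at this position, even though the entering group brings eight heavy atoms, a six-membered aromatic ring of carbon only and a hydrogen-bond acceptor where a single carbon stood before. Alongside the exchange of the whole ring, a 1.1-fold higher number from compound 1 to compound 2 (0.02 log units; within the scatter), this makes both steps at the amine end of the side chain flat, and no available measurement bears on the reason for this.

Still open, as far as these compounds go, is whether this flat picture holds for other kinds of group on that ring nitrogen, such as a carboxylic acid on a short chain, a plain hydrogen or a phenyl ring without the methoxy group. From the compounds shown here alone, it is equally open how far the read-out would move with a longer chain in place of the present side chain, or with an open-chain amine in place of the ring.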